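Swapping Hydroxyethyl for Cyano on the Benzyl Ring

The source may hold more compounds than are shown below. What is called first, only, known or untested is meant among the compounds shown, and "the series" means these compounds.

The measured compounds and their values:
compound 1, `CNC(=O)c1cc(C(=O)NC2CC2)cn(CC2CCCOC2)c1=O`: 2
compound 2, `CNC(=O)c1cc(C(=O)NC2CC2)cn(Cc2cccc3cc[nH]c23)c1=O`: 3.7
compound 3, `CNC(=O)c1cc(C(=O)NC2CC2)cn(Cc2cccc([C@@H](C)O)c2)c1=O`: 2.2

In a physicochemical assay for lipophilicity, at pH 7.4 (a lower number here means a more polar compound, a higher number a more lipophilic compound), compound 3 stands second highest of the three numbers. Its nearest neighbour is compound 1, and the step of a number 0.20 log units higher from compound 1 to compound 3 (within the scatter) lies within the scatter; its furthest is compound 2, separated by the step of a number 1.50 log units lower from compound 2 to compound 3 (beyond the scatter). Compound 4, `CNC(=O)c1cc(C(=O)NC2CC2)cn(Cc2cccc(C#N)c2)c1=O`, keeps the shared core and the benzyl group of compound 3 and differs only in this: cyano in place of 1-hydroxyethyl on an aromatic carbon.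

For the measured compounds named here, no measured step exchanges one substituent for another on an aromatic ring; the steps of a number 1.70 log units higher from compound 1 to compound 2 (beyond the scatter) and a number 1.50 log units lower from compound 2 to compound 3 (beyond the scatter) replace the whole group on the saturated chain carbon and are therefore only loosely related. The difference counted between compound 3 and compound 4 is small in heavy atoms, so no step beyond the scatter is expected. The step of a number 0.10 log units lower from compound 3 to compound 4 (within the scatter) is the estimate for compound 4. In this assay compound 4 is thus expected to give 2.1, with a range of 1.7 to 2.5.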

Compound 4, distribution coefficient: 2.6
Compound 4: middle estimate off by 0.50 log units, on the low side; measured number outside the range, above it.
By their numbers in this assay, from the lowest: compounds 1 and 3 (each within the scatter of the next); then compound 4; then compound 2.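

In this assay, for the compounds shown here, the exchange of 1-hydroxyethyl for cyano on this aromatic carbon gives the first measured substituent change on the ring (a number 0.40 log units higher from compound 3 to compound 4 (beyond the scatter)), so a swap of so few heavy atoms, which also removes the hydrogen-bond donor and the defined stereocentre, can move the number beyond the scatter. The benzyl series now separates from the oxan-3-yl group (a number 0.60 log units higher from compound 1 to compound 4 (beyond the scatter)), which compound 3 did not do, while 3-cyanophenyl remains well apart from 1H-indol-7-yl (a number 1.10 log units lower from compound 2 to compound 4 (beyond the scatter)). Nothing available accounts for the size of this step.

Going by these compounds, whether the step follows from losing the hydroxyl or from gaining the nitrile remains open. A methoxy or a hydroxymethyl group on the same aromatic carbon could separate these two readings in this assay, and an amine would extend the comparison further.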